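This account rests on a few compounds, and the source may have more. Where it says the series, first, only, none or still open, it means among the compounds named here.

Three related sulfonamides have been tested in an ADME assay on HEK293 cells (Homo sapiens) for cytotoxicity, read by resazurin assay, with a stated time of 48 h; on this read-out lower numbers stand for higher toxicity in this test and higher numbers for lower toxicity in this test. Compound 1 `Cc1cccc(S(=O)(=O)Nc2ccc3oc(-c4ccccc4)nc3c2)c1` gives 69000 nM in this assay. Compound 2 `O=S(=O)(Nc1ccc(-c2nc3ccccc3o2)cc1)c1ccc(C(F)(F)F)cc1` gives 94000 nM in this assay, a result that lies within the usual scatter of the number for compound 1, so the two cannot be told apart. For compound 3 `O=S(=O)(Nc1ccc(-c2nc3ccccc3o2)cc1)c1cccc(C(F)(F)F)c1` the result in this assay is a limit of the test rather than a number, > 100000 nM. Among the two numbers shown, compound 1 stands at the lower one, and one further result sits at the limit of > 100000 nM in this assay, at which 1 of the 3 values shown sits.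

Compound 4 `O=S(=O)(Nc1ccc2oc(-c3ccccc3)nc2c1)c1ccc(Cl)cc1` has not yet been measured in this assay. It differs from compound 1 in one place: 4-chlorophenyl in place of 3-methylphenyl on a sulfonyl sulfur. For the measured compounds named here, no pair of measured compounds shows this change, so its effect has to be judged from the compounds above, all of which sit at weak cytotoxicity within or near the same range.

Compound 4 is therefore expected to give about 80000 nM in this assay, between 35000 nM and 150000 nM. The expected step of a 1.2-fold higher number from compound 1 to compound 4 (0.06 log units; within the scatter) is no larger than the scatter, in no clear direction.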

Compound 4, half-maximal cytotoxic concentration: 65000 nM
Compound 4: the middle estimate sits 1.2-fold (0.09 log units) above what was measured; low and high end bracket the measured number.
By their numbers in this assay, from the lowest: compounds 4, 1 and 2 (each within the scatter of the next). At a limit, above all of these: compound 3.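

The exchange of 3-methylphenyl for 4-chlorophenyl on a sulfonyl sulfur now gives a direct comparison between two measured compounds that differ in one place: in this assay, the result is a 1.1-fold lower number from compound 1 to compound 4 (0.03 log units; within the scatter). Compound 1 and compound 4 therefore cannot be told apart in this test, so this one exchange, which keeps a single carbon-only aromatic ring at this place, has no effect that can be read here. The data shown offer no measured property that could explain this result.

A single pair says little about the place as a whole, since both groups are six-membered aromatic rings with no hydrogen-bond donors or acceptors. Going by these compounds, it remains open whether an amine, a carboxylic acid or a longer chain on the sulfonyl sulfur would give a step beyond the scatter.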